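The compounds below may be only part of what the source reports. "The series", "measured", "known", "first", "only" and "open" are said of these compounds alone.

Compound 3, drawn as `O=C(/C=C/c1ccc(O)cc1)O[C@H]1[C@H](O[C@H]2CCCC[C@H]2O)O[C@H](CO)[C@@H](O)[C@@H]1O`, is a sugar ester of a hydroxycinnamic acid carrying a hydroxycyclohexyl group. In a functional assay on A549 cells (Homo sapiens) for cytotoxicity, read by sulforhodamine B assay (on this read-out higher numbers stand for weaker inhibition and lower numbers for stronger inhibition), compound 3 gives > 10000 nM, which is a limit of the assay rather than a number. Two close relatives were measured alongside it. Compound 1 `O=C(/C=C/c1ccc(O)cc1)O[C@H]1[C@H](O[C@@H]2CCCC[C@H]2O)O[C@H](CO)[C@@H](O)[C@@H]1O` shares every atom and bond with compound 3 and differs only in one stereocentre at a saturated ring carbon; in this assay compound 1 gives > 10000 nM, again a limit. Compound 2 `O=C(/C=C\c1ccc(O)cc1)O[C@@H]1[C@H](O[C@@H]2CCCC[C@@H]2O)O[C@H](CO)[C@@H](O)[C@H]1O` differs from compound 1 in four stereo elements, including the double bond drawn as Z; in this assay compound 2 gives > 10000 nM, also a limit. Because all three values sit at the limit of > 10000 nM in this assay, at which 3 of the 3 values shown sit, the steps a step that the two limits leave unreadable from compound 1 to compound 2, a step that the two limits leave unreadable from compound 1 to compound 3 and a step that the two limits leave unreadable from compound 2 to compound 3 cannot be read in size or direction.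

Compound 4 `O=C(/C=C\c1ccc(O)cc1)O[C@H]1[C@H](O[C@H]2CCCC[C@H]2O)O[C@H](CO)[C@@H](O)[C@@H]1O` differs from compound 3 as follows: the two compounds have the same atoms and bonds and differ only in configuration as drawn: 1 of 8 stereo elements differ; a double bond is drawn E in compound 3 and Z in compound 4. Among the measured compounds shown here, no measured step isolates this change, and the only compound carrying the Z geometry, compound 2, sits at the same limit as the others. Compound 4 is therefore expected to remain at or beyond the limit, an estimated 15000 nM with a range from 5000 nM to 50000 nM, an expected step that the limit leaves unreadable from compound 3 to compound 4.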

Compound 4, half-maximal inhibitory concentration: > 10000 nM
Compound 4: no number, only a limit (the forecaster's own chance of this, stated with the estimate: 90%); the middle value does not contradict the limit.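

Compound 4, like compound 1, compound 2 and compound 3, gives only a limit and not a number, so no step among these compounds can be read in size or direction: the limit of > 10000 nM in this assay, at which 4 of the 4 values shown sit. The compounds shown leave open whether double-bond geometry or stereocentre configuration changes the result in this assay at all.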